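The compounds below may be only part of what the source reports. "The series", "measured", "known", "first", "only" and "open" are said of these compounds alone.

Compound 1 `CCC1(Cc2ccccc2)OS(=O)(=O)C=C1OCc1ccc(OC)cc1`: >= 200000 nM
Compound 2 `CC(C)C1(Cc2ccccc2)OS(=O)(=O)C=C1OCc1ccccc1`: >= 80000 nM

Both readings come from an ADME assay on HEL cells (Homo sapiens) for cytotoxicity, with a stated time of 3 days; a higher number here means that more compound is tolerated, a lower number that less compound is tolerated. The value for compound 1 is a limit of the assay rather than a measured number, namely (the limit of >= 200000 nM in this assay, at which 1 of the 2 values shown sits). The value for compound 2 is also a limit, namely (the limit of >= 80000 nM in this assay, at which 1 of the 2 values shown sits). Compound 2 therefore stands at a point where the assay stops reporting, and the only other compound shown stands at a limit as well, so no ordering between the two can be drawn.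

Compound 3 `O=S1(=O)C=C(OCc2ccccc2)C(Cc2ccccc2)(Cc2ccccc2)O1` has not yet been measured. It differs from compound 2 in one place: benzyl in place of isopropyl on a saturated ring carbon. Among the compounds with values here, no step between measured compounds is available, so the size of this change cannot be read from the data. A step of no more than the usual scatter is expected, in either direction. The expected step is a number no higher from compound 2 to compound 3 (the limit leaves the size open). Compound 3 is estimated to give 80000 nM in this assay, with a range from 25000 nM to 200000 nM, and the result may well again be a limit rather than a number.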

Compound 3, minimum cytotoxic concentration: 200000 nM
Compound 3: the middle estimate sits 2.5-fold (0.40 log units) below what was measured; the measured number falls inside the stated range.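

No step can be read between compound 2 and compound 3, because the value for compound 2 is a limit and not a number: the limit of >= 80000 nM in this assay, at which 1 of the 3 values shown sits. The compounds shown leave open whether benzyl in place of isopropyl on a saturated ring carbon changes the tolerated concentration at all.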